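A bromo on the sulfonyl phenyl: compound 4 from compound 2

This account rests on a few compounds, and the source may have more. Where it says the series, first, only, none or still open, it means among the compounds named here.

Compound 1, `COc1ccc(Nc2nc3ccccc3nc2S(=O)(=O)c2ccccc2)cc1`, gives 1510 nM in a functional assay on PC-3 cells (Homo sapiens) for cytotoxicity, read by MTT assay, with a stated time of 72 h; a higher number here means a weaker inhibitor, a lower number a stronger inhibitor. Compound 2, `Nc1ccc(Nc2nc3ccccc3nc2S(=O)(=O)c2ccccc2)cc1`, gives 5830 nM in this assay. Compound 3, `O=S(=O)(c1ccccc1)c1nc2ccccc2nc1Nc1ccc(C(F)(F)F)cc1`, gives 3550 nM in this assay.

Compound 2 has the highest number of the three. Its gap to compound 3 is small, a 1.6-fold lower number from compound 2 to compound 3 (0.22 log units; within the scatter), so the two cannot be ordered. Its gap to compound 1 is larger, a 3.9-fold higher number from compound 1 to compound 2 (0.59 log units; beyond the scatter), and the step from compound 1 to compound 3 is a 2.4-fold higher number from compound 1 to compound 3 (0.37 log units; beyond the scatter).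

Compound 4, `Nc1ccc(Nc2nc3ccccc3nc2S(=O)(=O)c2ccc(Br)cc2)cc1`, differs from compound 2 in one place: bromo in place of hydrogen on an aromatic carbon, on an aromatic carbon of a six-membered aromatic ring of carbon only, para to a large group; cut one bond further out, the change reads phenyl to 4-bromophenyl.

None of the three measured steps bears on this change. All of them alter the group on the aniline ring of the shared core, while the sulfonyl phenyl is the same in compounds 1, 2 and 3. For the measured compounds named here, there is no measured step on the sulfonyl phenyl, so the data give no direction for compound 4. The expected step from compound 2 is accordingly a 1.0-fold lower number from compound 2 to compound 4 (0.00 log units; within the scatter), none beyond the scatter, with a wide range to reflect the lack of a precedent. Compound 4 is therefore estimated at 5800 nM, with a range from 2000 nM to 17000 nM in this assay.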

Compound 4, half-maximal inhibitory concentration: 2330 nM
The estimate for compound 4 lay 2.5-fold (0.40 log units) above the measured number; the range from low to high includes it.
By their numbers in this assay, from the lowest: compounds 1, 4, 3 and 2 (each within the scatter of the next, the first and the last beyond it).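

The sulfonyl phenyl, the same in compounds 1, 2 and 3, proves responsive in this assay: the change from phenyl to 4-bromophenyl gives a 2.5-fold lower number from compound 2 to compound 4 (0.40 log units; beyond the scatter) and so makes compound 4 the stronger inhibitor of the pair. For the compounds shown here, this is the first measured step at a site other than the group carried on the aniline ring, and it shows that this part of the molecule can also shift the read-out beyond the scatter. Bromo adds only one heavy atom, on an aromatic carbon para to a large group, yet no information at hand accounts for the step.

The compounds shown leave open whether the lower number is particular to bromo or would also follow from chloro, fluoro, methyl or methoxy at the same place on the sulfonyl phenyl. They also leave open whether bromo would give a step in the same direction with the methoxy of compound 1 or the trifluoromethyl of compound 3 in place of the amino group of compound 4.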